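A few compounds are considered here, and "the series" means these few. Any claim that something is new, unique, unknown or untested is made for them only; others in the source may bear on it.

Compounds measured in an assay on nucleic acid for binding affinity to Quadruplex DNA (Homo sapiens), read by fluorescence, tested at 20 uM; on this read-out lower numbers stand for weaker stabilisation of the target and higher numbers for stronger stabilisation of the target against heat:
compound 1 `CC(C)(N)C(=O)NC1CCN(C(=O)Cn2ccc3ccncc32)CC1` gives 0.1 degrees C
compound 2 `CCOc1cc(CNCC2CCNCC2)ccc1OCc1ccc(Cl)cc1` gives 3.2 degrees C

Compound 1 stands lowest of the two numbers; compound 2 gives a number higher by a margin beyond the usual scatter. Compound 3 `CC(C)CC(N)C(=O)NC1CCN(C(=O)Cn2ccc3ccncc32)CC1` is compound 1 with 1-amino-3-methylbutyl in place of 1-amino-1-methylethyl on a carbonyl carbon. Among the measured compounds shown here, no measured pair shows this kind of change, so no step size is known for it. The shared core of compound 1 and compound 3 is unchanged, and the expectation is that the change from compound 1 to compound 3 leaves the read-out essentially where it is, with a number 0.40 degrees C higher from compound 1 to compound 3 (within the scatter) staying within the scatter. Compound 3 is therefore expected to give about 0.5 degrees C, in the range -0.6 degrees C to 1.8 degrees C.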

Compound 3, shift of the target's melting temperature: 0.3 degrees C
Estimate against measurement, compound 3: 0.20 degrees C above; low and high end bracket the measured number.
By their numbers in this assay, from the lowest: compounds 1 and 3 (each within the scatter of the next); then compound 2.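

In this assay, 1-amino-3-methylbutyl in place of 1-amino-1-methylethyl on a carbonyl carbon gives a number 0.20 degrees C higher from compound 1 to compound 3 (within the scatter). Among the compounds shown here, this is the first measured step at this position, and it shows that, in this one pair, the two groups do not separate the compounds on this read-out. No independent measurement bears on this result. Going by these compounds, whether a group of another kind at this place, such as a carboxylic acid or a phenyl ring, would give a number beyond the scatter remains open.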